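Swapping a chlorophenyl amide for a bromo-methylphenyl amide

The source may report more compounds than this note shows. Statements on the series, on what has been measured and on what is new or still open speak of the compounds shown alone.

Two compounds of one family share a core and differ only in the ring attached to the amide nitrogen. Compound 1 `O=C(COc1ccc(/C=C2\SC(=O)NC2=O)cc1)Nc1ccc(F)cc1` carries a fluoro group on that ring, and in a functional assay on KB cells (Homo sapiens) for inhibition (on this read-out higher numbers stand for weaker inhibition of growth and lower numbers for stronger inhibition of growth), compound 1 reaches only the limit > 100000 nM, so no number is known for it. Among the compounds with values here, compound 2 `O=C(COc1ccc(/C=C2\SC(=O)NC2=O)cc1)Nc1ccc(Cl)cc1` carries chloro instead, and in this assay compound 2 gives 50300 nM, the only number in this set. Within the data shown here, the step of an at least 1.9-fold lower number from compound 1 to compound 2 (0.29 log units; that floor lies within the scatter) shows that the chloro compound is the one with a measurable value, though the size of that step rests on a limit (the limit of > 100000 nM in this assay, at which 1 of the 2 values shown sits).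

Compound 3 `Cc1cc(Br)ccc1NC(=O)COc1ccc(/C=C2\SC(=O)NC2=O)cc1` takes the next change: 4-bromo-2-methylphenyl in place of 4-chlorophenyl on an amide-type nitrogen. Among the measured compounds shown here, only one measured step bears on it, and that step moved toward a lower number when chloro replaced fluoro, by an amount that cannot be separated from the scatter. On that single step, the expected change is a 1.7-fold lower number from compound 2 to compound 3 (0.22 log units; within the scatter). Compound 3 is therefore expected to give about 30000 nM, within 10000 nM to 100000 nM.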

Compound 3, concentration for 50% growth inhibition: > 100000 nM
Compound 3 was reported as a limit; the forecaster's own chance of this, stated with the estimate: 15%; at least 3.3-fold (0.52 log units) between middle value and limit.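

In this assay compound 3 gives > 100000 nM, which is a limit and not a number. On the ring on the amide-type nitrogen, the change to 4-bromo-2-methylphenyl reads as an at least 1.9-fold higher number from compound 2 to compound 3 (0.29 log units; that floor lies within the scatter), so it does not continue the earlier move toward a lower number, although this floor alone cannot establish a real loss of growth inhibition. The step that links the fluoro compound directly to the bromo-methyl compound cannot be read, and compound 2 remains the only compound with a measured number, so the series gives little to compare: the limit of > 100000 nM in this assay, at which 2 of the 3 values shown sit.

This change brings in bromine in place of chlorine and adds a methyl group in one move, so the compounds shown cannot say which of the two matters, or whether either does. A plain 4-bromophenyl ring would separate the halogen from the methyl, while a ring carrying an amine or a carboxylic acid would test whether a quite different group on the amide nitrogen's ring could give a clearly lower number than compound 2.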